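Adding a Methoxy Group and Toxicity toward Kidney Cells

The source may report more compounds than this note shows. Statements on the series, on what has been measured and on what is new or still open speak of the compounds shown alone.

Compound 1 `C[C@@H]1CC[C@@H]2[C@@H](C1)O[C@@H](c1ccc(O)cc1)CC2(C)O` and compound 2 `COc1cc([C@H]2CC(C)(O)[C@@H]3CC[C@@H](C)C[C@H]3O2)ccc1O` share one core, and compound 2 carries one extra group. In an ADME assay on MDCK cells (Canis lupus familiaris) for cytotoxicity, read by MTT assay, with a stated time of 48 h (on this read-out lower numbers stand for higher toxicity in this test and higher numbers for lower toxicity in this test), compound 1 gives 127000 nM, and compound 2 gives 411000 nM. The change between them is methoxy in place of hydrogen on an aromatic carbon, and it made a 3.2-fold higher number from compound 1 to compound 2 (0.51 log units; beyond the scatter). Compound 3 `COc1ccc([C@H]2CC(C)(F)[C@@H]3CC[C@@H](C)C[C@H]3O2)cc1OC` is built on a different core; the difference between the two cores is not broken down here. In this assay compound 3 gives 20000 nM, the lowest of the three numbers. Compound 4 `COc1cc([C@H]2CC(C)(F)[C@@H]3CC[C@@H](C)C[C@H]3O2)cc(OC)c1OC` has not yet been measured. It differs from compound 3 by methoxy in place of hydrogen on an aromatic carbon. Among the compounds with values here, this is the same kind of change as the one from compound 1 to compound 2, but not the same: there the entering group sat ortho to a hydroxy group, whereas here it sits ortho to a methoxy group and meta to a methoxy group. Because of the step of a 3.2-fold higher number from compound 1 to compound 2 (0.51 log units; beyond the scatter), a step in the same direction but of smaller size is expected: a 2.0-fold higher number from compound 3 to compound 4 (0.30 log units; within the scatter). Compound 4 is therefore expected to give about 40000 nM in this assay, most likely between 15000 nM and 120000 nM.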

Compound 4, half-maximal cytotoxic concentration: 568000 nM
Estimate against measurement, compound 4: 14-fold (1.15 log units) below; the measured number lies above the stated range.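

In this assay, methoxy in place of hydrogen on an aromatic carbon again gives a higher number, which here means lower toxicity in this test, and the new step is large (a 28-fold higher number from compound 3 to compound 4 (1.45 log units; beyond the scatter)). The direction of the change therefore carried over from one core to the other in these two pairs, but its size did not: the same change on two cores in this assay, a 3.2-fold higher number (0.51 log units; beyond the scatter) from compound 1 to compound 2 and a 28-fold higher number (1.45 log units; beyond the scatter) from compound 3 to compound 4, 8.8-fold (0.94 log units) apart, beyond the scatter of two such steps. This does not show what sets the size, as the two pairs differ in their cores and in the groups around the entering methoxy, and two steps cannot separate these influences or establish a rule for the whole series.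

The compounds shown leave open whether the large step depends on the fluorine of compound 3 and compound 4 or on the methoxy groups already on their aromatic ring. They also leave open whether an ethoxy group or a chlorine atom entering at the same place would give a step of similar size.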